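Changing the aryl group on the saturated ring carbon

The compounds below may be only part of what the source reports. "The series", "measured", "known", "first", "only" and "open" are said of these compounds alone.

Of the compounds shown here, three that share one core have been measured in a functional assay on A549 cells (Homo sapiens) for cytotoxicity, read by MTT assay, with a stated time of 72 h; on this read-out higher numbers stand for weaker inhibition and lower numbers for stronger inhibition. Compound 2 `CNC(=O)c1cc(Oc2ccc(C3=NNC(c4cccc(Br)c4)C3)cc2)ccn1` gives 2840 nM, the lowest of the three numbers. Compound 1 `CNC(=O)c1cc(Oc2ccc(C3=NNC(c4ccc(Cl)cc4Cl)C3)cc2)ccn1` gives 6930 nM, and the step of a 2.4-fold lower number from compound 1 to compound 2 (0.39 log units; beyond the scatter) lies beyond the scatter. Compound 3 `CNC(=O)c1cc(Oc2ccc(C3=NNC(c4cc(OC)c(OC)c(OC)c4)C3)cc2)ccn1` gives 37100 nM, the highest number of the set and the furthest from compound 2.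

Compound 4 `CNC(=O)c1cc(Oc2ccc(C3=NNC(c4ccc([N+](=O)[O-])cc4)C3)cc2)ccn1` differs from compound 2 by 4-nitrophenyl in place of 3-bromophenyl on a saturated ring carbon. Among the compounds with values here, the only measured step at this position, a 2.4-fold lower number from compound 1 to compound 2 (0.39 log units; beyond the scatter), was modest, while the values of compound 2 and compound 3 show that another group on the same saturated carbon can carry the number far upward. Within the data shown here, no measured step brings in 4-nitrophenyl itself, so the direction rests on these two comparisons alone. An upward step a 2.8-fold higher number from compound 2 to compound 4 (0.45 log units; beyond the scatter) is expected, beyond the scatter but short of the gap to compound 3. Compound 4 is estimated at 8000 nM, with a range from 2500 nM to 25000 nM.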

Compound 4, half-maximal inhibitory concentration: 19500 nM
For compound 4 the middle estimate is 2.4-fold (0.39 log units) below the measured one, and the stated range covers the measured number.
By their numbers in this assay, from the lowest: compound 2; then compound 1; then compounds 4 and 3 (each within the scatter of the next).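

In this assay, the change to 4-nitrophenyl gives a 6.9-fold higher number from compound 2 to compound 4 (0.84 log units; beyond the scatter) and a 2.8-fold higher number from compound 1 to compound 4 (0.45 log units; beyond the scatter), so a large upward move at this saturated ring carbon is no longer seen with compound 3 alone. Compound 4, at 19500 nM, and compound 3, at 37100 nM, lie within the scatter of each other, and among these four compounds the two aryl groups bearing halogen, in compound 1 and compound 2, give the lower numbers. No supporting evidence is available to explain this split.

The compounds shown leave open how much of the step from 3-bromophenyl to 4-nitrophenyl belongs to the group and how much to its place on the ring, which 4-bromophenyl and 3-nitrophenyl would separate. They also leave open how plain phenyl or an aminophenyl group would behave here.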